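The source may hold more compounds than are shown below. What is called first, only, known or untested is meant among the compounds shown, and "the series" means these compounds.

Of the compounds shown here, three have so far been measured in a functional assay on HeLa cells (Homo sapiens) for cytotoxicity, read by MTT assay, with a stated time of 2 days, tested at 0.1 uM; a lower number here means a stronger effect, a higher number a weaker effect of the compound at the concentration tested. In that setting compound 1 `COc1ccc(-c2cc3cc(-c4ccccc4)cc(C(C)=O)c3[nH]2)cc1` gives 80.5%, compound 2 `COc1ccc(-c2cc(C(C)=O)c3[nH]c(-c4ccc(OC)cc4)cc3c2)cc1` gives 74.5%, and compound 3 `CC(=O)c1cc(/C=C/c2ccc(F)cc2)cc2cc(-c3ccccc3)[nH]c12` gives 74.2%; the number for compound 3 lies within the scatter of both compound 2 and compound 1, so the three cannot be told apart. Compound 4 `COc1ccc(-c2cc3cc(/C=C/c4ccc(F)cc4)cc(C(C)=O)c3[nH]2)cc1` has not yet been measured. It differs from compound 3 by methoxy in place of hydrogen on an aromatic carbon. Among the measured compounds shown here, the one comparable step already seen, a number 6 percentage points lower from compound 1 to compound 2 (within the scatter), was the same change at the same kind of place and stayed within the scatter. Only a small step is therefore expected, a number 2.2 percentage points lower from compound 3 to compound 4 (within the scatter), with no clear direction. Compound 4 is estimated to give 72% in this assay, with a range from 60% to 84%.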

Compound 4, a percentage reported as activity, at one concentration (the size of the read-out at that concentration, not a potency): 90.5%
For compound 4 the middle estimate is 18.5 percentage points below the measured one; the measured number lies above the stated range.
By their numbers in this assay, from the lowest: compounds 3, 2, 1 and 4 (each within the scatter of the next, the first and the last beyond it).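

Methoxy in place of hydrogen can weaken the effect in this assay: on the core carrying 2-(4-fluorophenyl)ethenyl, it gives a number 16.3 percentage points higher from compound 3 to compound 4 (beyond the scatter). Putting 2-(4-fluorophenyl)ethenyl in place of 4-methoxyphenyl gives a number 16 percentage points higher from compound 2 to compound 4 (beyond the scatter), and putting it in place of phenyl gives a number 10 percentage points higher from compound 1 to compound 4 (within the scatter). The methoxy change therefore does not carry over from one core to the other: the same change on two cores in this assay, a number 6 percentage points lower (within the scatter) from compound 1 to compound 2 and a number 16.3 percentage points higher (beyond the scatter) from compound 3 to compound 4, 22.3 percentage points apart, beyond the scatter of two such steps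

The compounds shown leave open whether an amine or a hydroxyl group at this place would depend on the rest of the molecule in the same way. Each reading comes from a single concentration, so none of them gives a potency.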